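Extending the sulfur-side chain of compound 2

The source may report more compounds than this note shows. Statements on the series, on what has been measured and on what is new or still open speak of the compounds shown alone.

Measured compounds:
- compound 1, `CCCCNc1nc(SCC)nc2ncccc12`: 9200 nM
- compound 2, `CCCCCCNc1nc(SCC)nc2ncccc12`: 1400 nM
- compound 3, `CCCCCCCNc1nc(SCC)nc2ncccc12`: 2600 nM

In a functional assay on MDA-MB-231 cells (Homo sapiens) for cytotoxicity, read by neutral red uptake, with a stated time of 72 h (on this read-out lower numbers stand for stronger inhibition and higher numbers for weaker inhibition), compound 2 gives the lowest number of the three shown. The step of a 6.6-fold lower number from compound 1 to compound 2 (0.82 log units; beyond the scatter) lies beyond the scatter, while the step of a 1.9-fold higher number from compound 2 to compound 3 (0.27 log units; within the scatter) lies within the scatter, so compound 2 and compound 3 cannot be ordered.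

Compound 4, `CCCCCCNc1nc(SCCCCC)nc2ncccc12`, differs from compound 2 by propyl in place of hydrogen on a saturated chain carbon, two bonds along the chain from a sulfur, that is ethylsulfanyl becoming pentylsulfanyl. The measured steps all concern chain lengthening on the nitrogen side: a 6.6-fold lower number from compound 1 to compound 2 (0.82 log units; beyond the scatter) and a 3.5-fold lower number from compound 1 to compound 3 (0.55 log units; beyond the scatter) were modest lowerings, and a 1.9-fold higher number from compound 2 to compound 3 (0.27 log units; within the scatter) stayed within the scatter. Among the compounds with values here, no measured step touches the sulfur side, so these steps bear only loosely on the change. A lengthening of a chain by three carbons is therefore expected to shift this assay little, if at all, beyond the scatter.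

Compound 4 is expected to give about 1500 nM, with a plausible range from 500 nM to 4500 nM, a step of a 1.1-fold higher number from compound 2 to compound 4 (0.03 log units; within the scatter).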

Compound 4, half-maximal inhibitory concentration: 9000 nM
Compound 4: middle estimate off by 6.0-fold (0.78 log units), on the low side, outside the stated range (above it).
By their numbers in this assay, from the lowest: compounds 2 and 3 (each within the scatter of the next); then compounds 4 and 1 (each within the scatter of the next).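

Within the data shown here, the sulfur-side chain, which no earlier step touched, proves to matter in this assay: ethylsulfanyl becoming pentylsulfanyl gives a 6.4-fold higher number from compound 2 to compound 4 (0.81 log units; beyond the scatter). The addition of propyl therefore cannot be read as one general effect of a longer chain, as it lowered the number on the nitrogen side and raised it on the sulfur side. The two steps start from different compounds, and the gap between them is beyond the scatter: the same change on two cores in this assay, a 3.5-fold lower number (0.55 log units; beyond the scatter) from compound 1 to compound 3 and a 6.4-fold higher number (0.81 log units; beyond the scatter) from compound 2 to compound 4, 23-fold (1.36 log units) apart, beyond the scatter of two such steps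

The compounds shown leave open how the number runs between the two sulfur-side chain lengths, for example with propylsulfanyl or butylsulfanyl, and whether an amine at the end of the pentyl chain would change it. Also open, on these data alone, is whether pentylsulfanyl would raise the number in the same way on the shorter nitrogen-side chain of compound 1.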